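The compounds below may be only part of what the source reports. "The series", "measured", "known", "first", "only" and "open" are said of these compounds alone.

Of the compounds shown here, three share one core and have been measured in an in vitro assay on BHK cells for displacement of a labelled ligand from gastric inhibitory polypeptide receptor (Homo sapiens), read by scintillation proximity assay; a lower number here means a stronger inhibitor, a higher number a weaker inhibitor. Compound 1 is `O=C(O)CCNC(=O)c1ccc(CN(c2ccc(Cl)cc2)c2nc(-c3ccc(OC(F)(F)F)cc3)cs2)cc1` and gives 869 nM. Compound 2 is `O=C(O)CCNC(=O)c1ccc(CN(c2ccc3c(c2)CCC3)c2nc(-c3ccc(C(F)(F)F)cc3)cs2)cc1` and gives 1100 nM. Compound 3 is `O=C(O)CCNC(=O)c1ccc(CN(c2ccc3c(c2)CCCC3)c2nc(-c3ccc(Cl)c(Cl)c3)cs2)cc1` and gives 830 nM. Compound 2 thus sits alongside compound 1 and compound 3, with the gaps between all three falling within the usual scatter of this assay, so no one of them can be called stronger or weaker than the others on these numbers.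

The next compound, compound 4, is `Cc1cc(N(Cc2ccc(C(=O)NCCC(=O)O)cc2)c2nc(-c3ccc(C(F)(F)F)cc3)cs2)ccc1C(C)C`. It differs from compound 2 in one place: 4-isopropyl-3-methylphenyl in place of 2,3-dihydro-1H-inden-5-yl on a nitrogen on an aromatic ring. Among the compounds with values here, no measured pair that makes this kind of change is available, so its effect is unknown here. With three compounds standing so close together and nothing to suggest a direction, the step from compound 2 to compound 4 in this assay is expected to be small, a 1.1-fold lower number from compound 2 to compound 4 (0.04 log units; within the scatter), and not clearly beyond the scatter. Compound 4 is therefore estimated at 1000 nM, with a range from 400 nM to 2500 nM.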

Compound 4, half-maximal inhibitory concentration: 633 nM
Compound 4: middle estimate off by 1.6-fold (0.20 log units), on the high side; measured number inside the range.
By their numbers in this assay, from the lowest: compounds 4, 3, 1 and 2 (each within the scatter of the next).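

In this assay, 4-isopropyl-3-methylphenyl in place of 2,3-dihydro-1H-inden-5-yl on the nitrogen gives a 1.7-fold lower number from compound 2 to compound 4 (0.24 log units; within the scatter), so the two compounds cannot be told apart. Within the data shown here, this is the first single-place comparison, and it shows that the five-membered non-aromatic ring of carbon is not required at this position for a value in this range: an open-chain isopropyl and a methyl on the six-membered aromatic ring serve equally well here. Nothing available explains this result.

On these data alone, both groups contain carbon only, so it remains open how a group containing an amine, a hydroxyl or a carboxylic acid would read at this position. As far as these compounds go, it is also open what the isopropyl and the methyl each contribute alone, and how an unsubstituted phenyl would compare.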